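The compounds below may be only part of what the source reports. "The series", "measured", "known", "first", "only" and "open" are said of these compounds alone.

Compound 1 `O=C(Nc1cnc(NCc2c(F)ccc3c2CCO3)n2cnnc12)c1ccccc1` belongs to a small set of compounds built on one shared core and tested in a physicochemical assay for solubility, read by LC-MS, in phosphate buffer, with a stated time of 24 h, at pH 7.4; a higher number here means a more soluble compound, a lower number a less soluble compound. In this assay compound 1 gives 2000 nM, the lowest of the two numbers at hand. Compound 3 `CN(C)Cc1ccc(C(=O)Nc2cnc(NCc3c(F)ccc4c3CCO4)n3cnnc23)cc1`, carrying (dimethylamino)methyl in place of hydrogen on an aromatic carbon, gives 520000 nM. That is a 260-fold higher number from compound 1 to compound 3 (2.41 log units; beyond the scatter). Compound 2 `Cc1ncccc1-c1cnc(NCc2c(F)ccc3c2CCO3)c2n[nH]c(=O)n12` gives only a limit, < 2000 nM, which is the limit of < 2000 nM in this assay, at which 1 of the 3 values shown sits. Compound 4 `C[C@H]1CC(=O)N(c2cnc(NCc3c(F)ccc4c3CCO4)n3cnnc23)C1` is not yet measured; it differs from compound 1 by 4-methyl-2-oxopyrrolidin-1-yl in place of benzamido on an aromatic carbon. Among the compounds with values here, no measured step matches this change, since the single measured step alters another position with another group. A modest rise is expected, a 7.5-fold higher number from compound 1 to compound 4 (0.88 log units; beyond the scatter). Compound 4 is estimated at 15000 nM, between 3000 nM and 80000 nM.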

Compound 4, solubility: 200000 nM
Estimate against measurement, compound 4: 13-fold (1.12 log units) below, outside the stated range (above it).
By their numbers in this assay, from the lowest: compound 1; then compound 4; then compound 3.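

In this assay, the benzamido group itself can be replaced at this position, not only extended at its far end as in compound 3: putting 4-methyl-2-oxopyrrolidin-1-yl in its place gives a 100-fold higher number from compound 1 to compound 4 (2.00 log units; beyond the scatter). The swap removes the six-membered aromatic ring and the amide hydrogen, yet the step stays large. No measurement at hand explains this rise. On these data alone, it remains open whether the ring, the methyl or the defined stereocentre carries the change. An open-chain amide or a simple amine on this carbon might also behave differently.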